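Swapping methyl for chloro on compound 3

The source may report more compounds than this note shows. Statements on the series, on what has been measured and on what is new or still open speak of the compounds shown alone.

Of the compounds shown here, three sharing one core have been measured in a functional assay on MCF7 cells (Homo sapiens) for cytotoxicity, read by CellTiter-Glo, with a stated time of 5 days; a lower number here means a stronger inhibitor, a higher number a weaker inhibitor. Compound 1 `CC/C(=C(/c1ccc(/C=C/C(=O)O)cc1)c1ccc2[nH]ncc2c1)c1ccccc1` gives 6 nM, compound 2 `CC/C(=C(/c1ccc(/C=C/C(=O)O)cc1)c1ccc2[nH]ncc2c1)c1ccccc1Cl` gives 2 nM, and compound 3 `CC/C(=C(/c1ccc(/C=C/C(=O)O)cc1)c1ccc2[nH]ncc2c1)c1ccc(C#N)cc1C` gives 5 nM. Among these, a 1.2-fold lower number from compound 1 to compound 3 (0.08 log units; within the scatter) stays within the scatter, while a 2.5-fold higher number from compound 2 to compound 3 (0.40 log units; beyond the scatter) goes beyond it. Compound 3 therefore cannot be told apart from compound 1, and it sits on the weaker side of compound 2.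

Compound 4 `CC/C(=C(/c1ccc(/C=C/C(=O)O)cc1)c1ccc2[nH]ncc2c1)c1ccc(C#N)cc1Cl` carries one change: chloro in place of methyl on an aromatic carbon. Its 4-cyano-2-methylphenyl becomes 2-chloro-4-cyanophenyl. Within the data shown here, no measured pair makes this exact swap. The closest evidence is chloro in place of hydrogen, where a 3.0-fold lower number from compound 1 to compound 2 (0.48 log units; beyond the scatter) is a modest step towards a lower number. Compound 2, which also carries a chloro, reads 2 nM, so a small downward move is expected, probably not beyond the scatter. The expected change is a 1.7-fold lower number from compound 3 to compound 4 (0.22 log units; within the scatter). Compound 4 is estimated at 3 nM, with an expected range of 1.2 nM to 7 nM.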

Compound 4, half-maximal inhibitory concentration: 4 nM
Compound 4: the middle estimate sits 1.3-fold (0.12 log units) below what was measured, and the stated range covers the measured number.
By their numbers in this assay, from the lowest: compounds 2, 4, 3 and 1 (each within the scatter of the next, the first and the last beyond it).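

At this position, on a ring that also carries a cyano group, methyl and chloro cannot be told apart: there is a 1.3-fold lower number from compound 3 to compound 4 (0.10 log units; within the scatter). Two further steps also stay within the scatter, a 2.0-fold higher number from compound 2 to compound 4 (0.30 log units; within the scatter) for cyano in place of hydrogen and a 1.5-fold lower number from compound 1 to compound 4 (0.18 log units; within the scatter) for the whole 2-chloro-4-cyanophenyl in place of phenyl, so the separation seen for chloro alone, a 3.0-fold lower number from compound 1 to compound 2 (0.48 log units; beyond the scatter), does not appear with the cyano group present. Nothing available explains why these steps are so small.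

The compounds shown leave open whether a different group at this position, such as methoxy or an amine, would move the number beyond the scatter. They also leave open how methyl compares with chloro on a ring without the cyano group.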